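The source may hold more compounds than are shown below. What is called first, only, known or untested is meant among the compounds shown, and "the series" means these compounds.

Measured so far in an ADME assay on L6 cells (Rattus norvegicus) for cytotoxicity, read by resazurin assay, with a stated time of 72 h; a lower number here means a stronger inhibitor, a higher number a weaker inhibitor:
- compound 1 `OC(c1ccc(Cl)cc1)(c1cccnc1)c1ccc(Cl)cc1F` gives 59400 nM
- compound 2 `OC(c1ccc(Cl)cc1)(c1cccnc1)c1cccs1` gives 67700 nM

Among the compounds with values here, compound 2 stands within the scatter of compound 1, the only other measured compound, so the two values set no order. Compound 3 `OC(c1cccnc1)(c1cccs1)c1ccc(Cl)cc1F` is not yet measured in this assay and differs from compound 2 by fluoro in place of hydrogen on an aromatic carbon. Within the data shown here, no measured pair shows this change alone. The expected 1.1-fold lower number from compound 2 to compound 3 (0.05 log units; within the scatter) stays within the scatter, with no real shift in either direction. For compound 3 the estimated value is 60000 nM with a range of 30000 nM to 115000 nM expected.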

Compound 3, half-maximal inhibitory concentration: > 100000 nM
Compound 3 gave a limit, no number (the forecaster's own chance of this, stated with the estimate: 5%); middle value at least 1.6-fold (0.22 log units) away from the limit.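

In this assay compound 3 gives no number, only a limit: the limit of > 100000 nM in this assay, at which 1 of the 3 values shown sits. Fluoro in place of hydrogen on an aromatic carbon, ortho to a large group and meta to a chloro group, gives an at least 1.4-fold higher number from compound 2 to compound 3 (0.16 log units; that floor lies within the scatter). Thiophen-2-yl in place of 4-chlorophenyl gives an at least 1.6-fold higher number from compound 1 to compound 3 (0.22 log units; that floor lies within the scatter); both floors lie within the scatter, so neither change is shown to shift the value.

As far as these compounds go, the true size of each step remains unknown. Also open, from the compounds shown here alone, is what an amine or a methoxy group on that same aromatic carbon would give.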